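A few compounds are considered here, and "the series" means these few. Any claim that something is new, unique, unknown or untested is made for them only; others in the source may bear on it.

Compound 1, `CC1(C)CCc2cc(C(=O)/C=C/c3ccc(OCc4cn(Cc5ccc([N+](=O)[O-])cc5)nn4)cc3)c(O)cc2O1`, gives 109000 nM in a functional assay on HepG2 cells (Homo sapiens) for antiproliferative activity, read by MTT assay; a higher number here means a weaker inhibitor, a lower number a stronger inhibitor.
Compound 2, `CCCCCn1cc(COc2ccc(/C=C/C(=O)c3cc4c(cc3O)OC(C)(C)CC4)cc2)nn1`, gives 95800 nM in this assay.
Compound 3, `CC1(C)CCc2c(ccc(C(=O)/C=C/c3ccc(OCc4cn(Cc5ccc([N+](=O)[O-])cc5)nn4)cc3)c2O)O1`, gives 69900 nM in this assay.

All three share a chalcone-type backbone carrying a triazole on one end, and they differ either in the group on the triazole or in how the chromane-like portion is joined. Going from compound 1 to compound 2, the change is butyl in place of 4-nitrophenyl on a saturated chain carbon bound to an aromatic nitrogen, and in this assay this gave a 1.1-fold lower number from compound 1 to compound 2 (0.06 log units; within the scatter), a step that does not rise above the noise of repeated measurement. Compound 3 has the same atoms as compound 1 joined differently; the difference between the two cores is not broken down here. The values of compound 3, compound 2 and compound 1 all lie within the scatter of one another, so none of them can be set apart as more or less active.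

Compound 4, `CCCCCn1cc(COc2ccc(/C=C/C(=O)c3ccc4c(c3O)CCC(C)(C)O4)cc2)nn1`, has not yet been measured. It stands to compound 3 as compound 2 stands to compound 1: the change is butyl in place of 4-nitrophenyl on a saturated chain carbon bound to an aromatic nitrogen, made at the same place. Because the earlier step was a 1.1-fold lower number from compound 1 to compound 2 (0.06 log units; within the scatter), the step from compound 3 to compound 4 in this assay is expected to be a 1.1-fold lower number from compound 3 to compound 4 (0.05 log units; within the scatter). On that basis compound 4 is estimated to give 63000 nM in this assay, most likely between 30000 nM and 130000 nM.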

Compound 4, half-maximal inhibitory concentration: 9820 nM
Compound 4: the middle estimate sits 6.4-fold (0.81 log units) above what was measured, and the stated range ends above it.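

In this assay, putting butyl in place of 4-nitrophenyl on a saturated chain carbon bound to an aromatic nitrogen (read one bond further out, 4-nitrobenzyl to pentyl) gave a 7.1-fold lower number from compound 3 to compound 4 (0.85 log units; beyond the scatter), a step that stands clear of the noise of repeated measurement. This change therefore does not carry over at the same size from one core to the other, so the result of the swap on one core is a poor guide to its result on the other in this series: the same change on two cores in this assay, a 1.1-fold lower number (0.06 log units; within the scatter) from compound 1 to compound 2 and a 7.1-fold lower number (0.85 log units; beyond the scatter) from compound 3 to compound 4, 6.3-fold (0.80 log units) apart, beyond the scatter of two such steps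

What this does not show is why the two cores differ, or whether the gap would hold for any other swap, since it rests on a single pair of compounds on each core and the cores themselves are not broken down into smaller changes.

The compounds shown leave open whether the larger step on the core of compound 3 comes from losing the nitro group, losing the aromatic ring, or gaining the chain. A plain benzyl group, a longer chain or a chain ending in an amine, placed on both cores, would begin to separate these possibilities.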